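Swapping the ring on the amide: from compound 2 to compound 3

This account rests on a few compounds, and the source may have more. Where it says the series, first, only, none or still open, it means among the compounds named here.

Compound 1 `CNC(=O)[C@H]1O[C@@H](n2cnc3c(NCc4cc(Cl)ccc4OCC(N)=O)ncnc32)[C@H](O)[C@@H]1N` and compound 2 `CNC(=O)[C@H]1O[C@@H](n2cnc3c(NCc4cc(Cl)ccc4OCC(=O)N4CCCCC4)ncnc32)[C@H](O)[C@@H]1N` share one core and differ only at the carbonyl carbon of the side chain. In an assay on isolated protein for binding affinity to adenosine receptor A3 (Homo sapiens) (on this read-out higher numbers stand for weaker inhibition and lower numbers for stronger inhibition), compound 1 gives 6.8 nM, and compound 2 gives 18 nM, which is the higher of the two numbers shown. Among the compounds with values here, the only measured step, a 2.6-fold higher number from compound 1 to compound 2 (0.42 log units; beyond the scatter), came with piperazin-1-yl in place of piperidin-1-yl on a carbonyl carbon being absent; that step replaced an amino group with a piperidin-1-yl ring and raised the number modestly. Compound 3 `CNC(=O)[C@H]1O[C@@H](n2cnc3c(NCc4cc(Cl)ccc4OCC(=O)N4CCNCC4)ncnc32)[C@H](O)[C@@H]1N` keeps the ring but changes it: piperazin-1-yl in place of piperidin-1-yl on a carbonyl carbon. Within the data shown here, no measured step covers this exact exchange, so the expectation rests on compound 2 alone, with the step to compound 1 as the only guide to how much this position can move the number. A small change, if any, is expected, as a 1.5-fold lower number from compound 2 to compound 3 (0.18 log units; within the scatter), leaving compound 3 near compound 2. Compound 3 is therefore estimated at 12 nM in this assay, within a range from 5 nM to 30 nM.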

Compound 3, inhibition constant: 9.4 nM
Beside the measured number, compound 3's estimate is 1.3-fold (0.11 log units) above it, within the range that was stated.
By their numbers in this assay, from the lowest: compounds 1, 3 and 2 (each within the scatter of the next, the first and the last beyond it).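

Exchanging piperidin-1-yl for piperazin-1-yl on the carbonyl carbon adds a second ring nitrogen and gives a 1.9-fold lower number from compound 2 to compound 3 (0.28 log units; within the scatter) in this assay so this exchange does not separate the two rings. A ring on this carbonyl carbon also does not always set a compound apart from the plain amino group: piperidin-1-yl gives a 2.6-fold higher number from compound 1 to compound 2 (0.42 log units; beyond the scatter) while piperazin-1-yl gives a 1.4-fold higher number from compound 1 to compound 3 (0.14 log units; within the scatter) in the same assay. Nothing available explains these numbers.

The compounds shown leave open how other rings on this carbonyl carbon would read, such as morpholin-4-yl, which carries an oxygen atom, or 4-methylpiperazin-1-yl. They also leave open where an open-chain group such as dimethylamino would fall.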